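The source may hold more compounds than are shown below. What is called first, only, known or untested is meant among the compounds shown, and "the series" means these compounds.

Measured so far:
compound 1, `C=C(Br)C(=O)Nc1cccc(/C=C2\SC(=O)N(Cc3ccc(C)cc3)C2=O)c1`: 1200 nM
compound 2, `Nc1cccc(/C=C2\SC(=O)N(Cc3ccccc3)C2=O)c1`: > 250000 nM

Compound 1 gives 1200 nM in a functional assay on HeLa cells (Homo sapiens) for cytotoxicity, read by cell counting, with a stated time of 4 days; a lower number here means a stronger inhibitor, a higher number a weaker inhibitor. Within the data shown here, for compound 2 the result in this assay is a limit of the assay, > 250000 nM, and not a number; it is the one value sitting at the limit of > 250000 nM in this assay, at which 1 of the 2 values shown sits. Compound 2 thus stands at the weak end of what is shown, and compound 1 is the only point with a measured concentration.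

Compound 3, `C=C(Br)C(=O)Nc1cccc(/C=C2\SC(=O)N(Cc3ccccc3)C2=O)c1`, is not yet measured in this assay. It differs from compound 2 by (1-bromoethenyl)carbonyl in place of hydrogen on a nitrogen on an aromatic ring; compound 1 carries this same ((1-bromoethenyl)carbonyl)amino group. Among the measured compounds shown here, no step between measured compounds is on hand, so the step from compound 2 to compound 3 has to be judged from the two values alone. Compound 2 sits at a limit of the assay. Compound 1, with the same group present, gives 1200 nM. The step is expected to be large and toward stronger inhibition, a drop out of the limit into the measurable range, an at least 120-fold lower number from compound 2 to compound 3 (2.09 log units; beyond the scatter). Compound 3 is therefore expected to give about 2000 nM, within 500 nM to 8000 nM.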

Compound 3, half-maximal inhibitory concentration: 1400 nM
The estimate for compound 3 lay 1.4-fold (0.15 log units) above the measured number, and the stated range covers the measured number.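

Among these compounds, on the nitrogen on an aromatic ring, (1-bromoethenyl)carbonyl in place of hydrogen gives, in this assay, an at least 170-fold lower number from compound 2 to compound 3 (2.25 log units; beyond the scatter), the first step at this position between compounds that differ in one place. This size is a bound and not an exact figure, because compound 2 stands at a limit of the assay: the limit of > 250000 nM in this assay, at which 1 of the 3 values shown sits. Hydrogen in place of methyl on an aromatic carbon gives a 1.2-fold higher number from compound 1 to compound 3 (0.07 log units; within the scatter), so in this pair the measurable inhibition with the ((1-bromoethenyl)carbonyl)amino group does not depend on that methyl.

The compounds shown carry only this one group on the nitrogen, so they leave open whether a plain acetyl group or a (1-chloroethenyl)carbonyl group there would also bring the number into the measurable range, and thus how much of the step rests on the bromine or on the double bond. They also leave open whether a methoxy group or a chlorine atom in place of the methyl on the aromatic carbon would stay within the scatter as well.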